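This account rests on a few compounds, and the source may have more. Where it says the series, first, only, none or still open, it means among the compounds named here.

Measured in an ADME assay on HepG2 cells (Homo sapiens) for cytotoxicity, read by MTT assay, with a stated time of 72 h; a higher number here means a weaker inhibitor, a lower number a stronger inhibitor:
- compound 1 `Cc1ccc(S(=O)(=O)Cc2nc(Nc3ccccc3)c3ccccc3n2)cc1`: "nd(insoluble)" (no result reported)
- compound 2 `Cc1ccc(S(=O)(=O)Cc2nc(Nc3cccc(C(F)(F)F)c3)c3ccccc3n2)cc1`: > 25000 nM
- compound 3 `Cc1ccc(S(=O)(=O)Cc2nc(Nc3cccc(Br)c3)c3ccccc3n2)cc1`: > 15000 nM

Compound 1 has no number to start from: "nd(insoluble)" (no result reported). For compound 2, > 25000 nM is a limit. For compound 3, > 15000 nM is also a limit. Compound 4 `Cc1ccc(S(=O)(=O)Cc2nc(Nc3ccccc3)c3cc([N+](=O)[O-])ccc3n2)cc1` is the core of compound 1 with one change: nitro in place of hydrogen on an aromatic carbon. Within the data shown here, the only measured step is a step that the two limits leave unreadable from compound 2 to compound 3, and it concerns a different substitution, so no step size can be carried over. With no start value, no size or direction of step can be stated in this assay. The expectation is that the result falls near the two limits, and it may well be reported only as a limit. Compound 4 is expected at 20000 nM, with an estimated range of 7000 nM to 50000 nM.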

Compound 4, half-maximal inhibitory concentration: > 25000 nM
Compound 4 was reported as a limit (the forecaster's own chance of this, stated with the estimate: 60%); middle value at least 1.2-fold (0.09 log units) away from the limit.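

No new step can be read from compound 1 to compound 4: compound 1 has no number, and compound 4 is reported only as a limit. The compounds shown leave open whether nitro in place of hydrogen changes the result in this assay.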